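From methyl to benzyl: notes on compound 3

This account rests on a few compounds, and the source may have more. Where it says the series, first, only, none or still open, it means among the compounds named here.

Measured so far in a functional assay on MCF7 cells (Homo sapiens) for cytotoxicity, read by MTT assay, with a stated time of 48 h (on this read-out lower numbers stand for stronger inhibition of growth and higher numbers for weaker inhibition of growth), with these results:
- compound 1 `Cc1nc2cc(Cl)c(Cl)cc2[nH]1` gives 28000 nM in this test
- compound 2 `Cn1c(C(F)(F)F)nc2cc(Cl)c(Cl)cc21` gives 39000 nM in this test

Compound 1 at 28000 nM and compound 2 at 39000 nM lie within the usual scatter of each other. The change to compound 3 `FC(F)(F)c1nc2cc(Cl)c(Cl)cc2n1Cc1ccccc1` is phenyl in place of hydrogen on a saturated chain carbon bound to an aromatic nitrogen, which reads as methyl to benzyl. Among the compounds with values here, no measured pair shows the effect of this change, so the expectation starts only from compound 2 at 39000 nM in this series. In this assay the expected step of a 2.6-fold lower number from compound 2 to compound 3 (0.41 log units; beyond the scatter) is modest, toward a lower number and slightly beyond the scatter. For compound 3 the estimated value is 15000 nM (expected range 5000 nM to 50000 nM).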

Compound 3, concentration for 50% growth inhibition: 8700 nM
The estimate for compound 3 lay 1.7-fold (0.24 log units) above the measured number; low and high end bracket the measured number.
By their numbers in this assay, from the lowest: compound 3; then compounds 1 and 2 (each within the scatter of the next).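

In this assay, phenyl in place of hydrogen on a saturated chain carbon bound to an aromatic nitrogen, read as methyl to benzyl, gives a 4.5-fold lower number from compound 2 to compound 3 (0.65 log units; beyond the scatter). Within the data shown here, this is the first single-place change, and it shows that this position tolerates the added phenyl ring and that the number moves toward stronger inhibition of growth. Nothing measured on these compounds accounts for the step.

As far as these compounds go, whether the shift needs the aromatic ring itself, or would also come with a longer chain such as propyl or with cyclohexylmethyl, remains open. So does whether an amine or a carboxylic acid carried on the phenyl ring would move the number further, and whether methyl to benzyl gives a similar step with another group in place of trifluoromethyl.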